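This account rests on a few compounds, and the source may have more. Where it says the series, first, only, none or still open, it means among the compounds named here.

Working notes on the series, with results so far in a functional assay on HCT-116 cells (Homo sapiens) for cytotoxicity, read by MTT assay, with a stated time of 72 h; a higher number here means a weaker inhibitor, a lower number a stronger inhibitor

compound 1 `COc1cccc(CNC(=O)c2nc(Br)c3cccnc3c2N[C@H]2CC[C@H](N)CC2)c1` gives 6000 nM
compound 2 `N[C@H]1CC[C@H](Nc2c(C(=O)NCc3ccccn3)nc(Br)c3cccnc23)CC1` is recorded as "not determined" (no result reported)
compound 3 `N[C@H]1CC[C@H](Nc2c(C(=O)NCc3cccs3)nc(Br)c3cccnc23)CC1` is recorded as "not determined" (no result reported)

Compound 3 has no place on the scale of this assay and compound 2 is in the same position. No number was reported for either of them. Going by the values given here, only one measured value is therefore available: compound 1 at 6000 nM in this series. Among the compounds with values here, no step between measured compounds exists, so the data give no direct measure of how far a change on the amide nitrogen can move the result.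

The next compound is compound 4 `N[C@H]1CC[C@H](Nc2c(C(=O)NC3CCCCC3)nc(Br)c3cccnc23)CC1`, which is still to be measured. The structural change is cyclohexyl in place of (thiophen-2-yl)methyl on an amide-type nitrogen with cyclohexyl in place of (thiophen-2-yl)methyl on an amide-type nitrogen.

With compound 3 unmeasured, this change has no starting number. The expectation is therefore set against compound 1 at 6000 nM as the only anchor, and no shift beyond the scatter is expected in either direction. The range is kept wide since it rests on a single value. For compound 4 the estimated value in this assay is 5000 nM, with an expected range from 1500 nM to 20000 nM as its limits.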

Compound 4, half-maximal inhibitory concentration: > 10000 nM
Compound 4: a limit, no number; the forecaster's own chance of this, stated with the estimate: 15%; middle value at least 2.0-fold (0.30 log units) from the limit.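

In this assay compound 4 gives > 10000 nM as a limit of the assay and not a number, so the reading ends at this point: the limit of > 10000 nM in this assay, at which 1 of the 4 values shown sits.

From the compounds shown here alone, the series now has its first readable change on the amide-type nitrogen, with an at least 1.6-fold higher number from compound 1 to compound 4 (0.22 log units; that floor lies within the scatter) as the step, and since only its floor is known, its true size stays unknown. What it adds is limited but real: with cyclohexyl on this nitrogen in place of 3-methoxybenzyl, there is no sign of a lower number, so a non-aromatic carbon ring at this position brings no gain in cytotoxicity over compound 1, while the steps from compound 2 and compound 3 cannot be read, as neither has a reported result.

Going by these compounds, it remains open how far the result for compound 4 lies past the limit, and whether the aromatic ring of the 3-methoxybenzyl group matters at all. Also open, on these data alone, is whether a different group on this nitrogen, such as an unsubstituted benzyl or a longer chain ending in an amine or a carboxylic acid, would move the number lower.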